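Taking the phenyl off compound 3

This account rests on a few compounds, and the source may have more. Where it says the series, first, only, none or still open, it means among the compounds named here.

In a functional assay on the whole organism with Mus musculus as the target, in the maximal electroshock model (on this read-out lower numbers stand for an effect already at smaller amounts and higher numbers for an effect only at larger amounts of compound), compound 1 (`c1ccc(-c2ccccc2OCCn2ccnc2)cc1`) gives 15.5 mg/kg and compound 2 (`c1ccc(-c2cccc(OCCn3ccnc3)c2)cc1`) gives 20.5 mg/kg, two values within the scatter of each other. Compound 3 (`c1ccc(-c2ccc(OCCn3ccnc3)cc2)cc1`) gives 44 mg/kg, the highest number of the three and beyond the scatter from both of the others.

Compound 4 (`c1ccc(OCCn2ccnc2)cc1`) comes from compound 3 with hydrogen in place of phenyl on an aromatic carbon. Going by the values given here, all three measured compounds carry the phenyl, so no measured pair shows what its loss does, and the expectation is correspondingly loose. Among the compounds with values here, the only guide is the spread of the three numbers, whose top is compound 3 at 44 mg/kg. The expected outcome in this assay is no step beyond the scatter (a 1.1-fold higher number from compound 3 to compound 4 (0.06 log units; within the scatter)), with a slight lean toward a higher number. Compound 4 is estimated at 50 mg/kg (expected range 22 mg/kg to 110 mg/kg).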

Compound 4, dose for half-maximal effect: 130 mg/kg
Beside the measured number, compound 4's estimate is 2.6-fold (0.41 log units) below it, outside the stated range (above it).
By their numbers in this assay, from the lowest: compounds 1 and 2 (each within the scatter of the next); then compound 3; then compound 4.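

In this assay, taking away the phenyl is the first change shown on this aromatic carbon, and it is not silent: even compound 3, with the highest number among the phenyl compounds, lies below the compound without the group (a 3.0-fold higher number from compound 3 to compound 4 (0.47 log units; beyond the scatter)). The gap is wider from the other two phenyl compounds (a 6.3-fold higher number from compound 2 to compound 4 (0.80 log units; beyond the scatter); an 8.4-fold higher number from compound 1 to compound 4 (0.92 log units; beyond the scatter)), so each of the three phenyl compounds has a lower number than compound 4, wherever its phenyl sits. Nothing given here explains why the phenyl matters for this read-out.

The compounds shown leave open whether a methyl or a chlorine on that aromatic carbon would give a number closer to compound 3 or to compound 4. They also leave open whether a second phenyl is needed at all, or whether a cyclohexyl in its place would serve as well.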